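This account rests on a few compounds, and the source may have more. Where it says the series, first, only, none or still open, it means among the compounds named here.

Compound 1 `COc1cc(/C=C/C2=CC(=O)CC(c3ccc(O)c(OC)c3)N2CCCO)ccc1O` in an ADME assay on CHO-K1 cells (Cricetulus griseus) for activation, read by fluorescence, tested at 1 uM (a higher number here means a weaker effect of the compound at the concentration tested, a lower number a stronger effect), gives 91.8%.
Compound 2 `COCCCN1C(/C=C/c2ccc(O)cc2)=CC(=O)CC1c1ccc(O)cc1` in this assay gives 97.8%.
Compound 3 `COc1cc(/C=C/C(=O)/C=C(/C=C/c2ccc(O)c(OC)c2)NCCCO)ccc1O` in this assay gives 90.4%.

On paper compound 3 carries the smallest of the three numbers, yet compound 1 sits within the usual scatter of it and so does compound 2, so the three cannot be told apart in this assay; all of them show only a weak effect at the tested concentration. Compound 4 `COCCCNC(=C\C(=O)/C=C/c1ccc(O)c(OC)c1)/C=C/c1ccc(O)c(OC)c1` differs from compound 3 by methyl in place of hydrogen on an oxygen on a saturated carbon. Among the compounds with values here, no measured pair shows this change by itself, so nothing direct can be drawn on it. Because compound 3 gives 90.4% in this assay and compound 1 gives 91.8% and compound 2 gives 97.8%, all close together and high, the step of a number 2.6 percentage points higher from compound 3 to compound 4 (within the scatter) is expected to stay within the scatter, with no direction beyond it. Compound 4 is therefore estimated at 93%, in a range from 84% to 101%.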

Compound 4, a percentage reported as activity, at one concentration (the size of the read-out at that concentration, not a potency): 98.3%
Compound 4: middle estimate off by 5.3 percentage points, on the low side, within the range that was stated.
By their numbers in this assay, from the lowest: compounds 3, 1, 2 and 4 (each within the scatter of the next).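

Methyl in place of hydrogen on an oxygen on a saturated carbon now has a direct reading: in this assay it gives a number 7.9 percentage points higher from compound 3 to compound 4 (within the scatter). At this position, hydroxy and methoxy therefore cannot be told apart, and both compounds still show only a weak effect at the tested concentration. No measurement here offers an explanation for this result.

On these data alone, whether an amine or a carboxylic acid in this place would move the number beyond the scatter remains open. So does the outcome for a longer chain.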